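Chain length and monoamine oxidase A inhibition

This account rests on a few compounds, and the source may have more. Where it says the series, first, only, none or still open, it means among the compounds named here.

Measured so far:
Compound 1, `C#CCN(C)CCCCCOc1ccc2c(c1)CCC2=O`: 31%
Compound 2, `C#CCN(C)CCCOc1ccc2c(c1)OCCC2=O`: 32.1%

Both compounds were tested in an ADME assay on BTI cells for inhibition of Amine oxidase [flavin-containing] A (Homo sapiens), read by fluorescence and Amplex Red, with a stated time of 15 min, tested at 100 uM; a higher number here means more inhibition at the concentration tested (going by the name of the read-out), a lower number less inhibition. Compound 2 gives 32.1%, and compound 1 gives 31%, a number that lies within the usual scatter of compound 2, so the two values cannot be told apart. Compound 3, `C#CCN(C)CCCCOc1ccc2c(c1)OCCC2=O`, has not yet been measured in this assay. It differs from compound 2 in one place: (methyl(propargyl)amino)methyl in place of methyl(propargyl)amino on a saturated chain carbon, three bonds along the chain from an oxygen on an aromatic ring. The saturated chain that runs from the oxygen on the aromatic ring to the amine is thus extended, while the core of compound 2 and the rest of the molecule are unchanged. Going by the values given here, no pair of measured compounds differs in a single place, so no measured step is available to guide the expectation. Compound 1 and compound 2 carry chains of different length on different cores and give nearly the same number, which gives no sign that chain length alone moves the value in this assay. Compound 3 is therefore expected to show a step of a number 1.9 percentage points higher from compound 2 to compound 3 (within the scatter), that is, none beyond the scatter. The estimate for compound 3 is 34%, with a range from 20% to 50%.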

Compound 3, a percentage reported as inhibition, at one concentration (the size of the read-out at that concentration, not a potency): 22.8%
The estimate for compound 3 lay 11.2 percentage points above the measured number; low and high end bracket the measured number.
By their numbers in this assay, from the lowest: compounds 3, 1 and 2 (each within the scatter of the next).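

Going by these compounds alone, the change from methyl(propargyl)amino to (methyl(propargyl)amino)methyl, on a saturated chain carbon, three bonds along the chain from an oxygen on an aromatic ring, provides the first comparison of compounds that differ in one place in this assay, with a number 9.3 percentage points lower from compound 2 to compound 3 (within the scatter). On this core, then, the added chain carbon does not separate compound 3 from compound 2 beyond the scatter, so this single comparison gives no evidence that the position is sensitive to this change, while compound 1 differs from both in more than one place and cannot add to the reading. No supporting measurement bears on this result, so it offers no explanation of the step.

The compounds shown leave open whether a longer chain, such as 2-(methyl(propargyl)amino)ethyl at the same place on the core of compound 2, would give a step beyond the scatter. They also leave open whether the same chain change would read alike with an allyl group or a benzyl group on the amine in place of the propargyl group.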